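Removing the amino group from compound 1

The source may report more compounds than this note shows. Statements on the series, on what has been measured and on what is new or still open speak of the compounds shown alone.

Measured in a functional assay on HeLa cells (Homo sapiens) for cytotoxicity, read by MTT assay, with a stated time of 24 h; on this read-out lower numbers stand for stronger inhibition and higher numbers for weaker inhibition:
Compound 1 `Nc1cccn2cc(Cc3ccccc3)c(=O)nc12`: 112000 nM
Compound 2 `Nc1cccn2cc(Cc3ccc(F)cc3)c(=O)nc12`: > 1000000 nM (a limit, not a number)
Compound 3 `O=c1nc2ccc(Cl)cn2cc1Cc1ccc([N+](=O)[O-])cc1`: 928000 nM

Compound 1 holds the lower of the two true numbers, and compound 3 stands higher at 928000 nM. Compound 4 `O=c1nc2ccccn2cc1Cc1ccccc1` has hydrogen in place of amino on an aromatic carbon. Among the measured compounds shown here, no measured step makes this exact change. The nearest is an at least 8.9-fold higher number from compound 1 to compound 2 (0.95 log units; beyond the scatter), with fluoro in place of hydrogen on an aromatic carbon elsewhere in the molecule. Compound 3 also lacks the amino group and differs in other places, while compound 2 keeps it and still stands high. A moderate move towards a higher number is therefore expected in this assay, with little certainty. The estimated step is a 3.1-fold higher number from compound 1 to compound 4 (0.49 log units; beyond the scatter). For compound 4 the expected value is 350000 nM, with an estimated range from 100000 nM to 1000000 nM.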

Compound 4, half-maximal inhibitory concentration: > 1000000 nM
Compound 4 gave a limit, no number; the forecaster's own chance of this, stated with the estimate: 20%; at least 2.8-fold (0.45 log units) between middle value and limit.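

In this assay, the amino group proves to count on its own at this aromatic carbon: with hydrogen in its place, the step is an at least 8.9-fold higher number from compound 1 to compound 4 (0.95 log units; beyond the scatter). Compound 4 gives > 1000000 nM, which is a limit and not a number, so this step has a floor but no known size. Both single changes shown from compound 1 end at the same limit: the limit of > 1000000 nM in this assay, at which 2 of the 4 values shown sit.

From the compounds shown here alone, how far compound 4 truly stands from compound 1 remains open. So does whether a methyl, a hydroxyl or a methylamino group on this carbon would keep the number of compound 1.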